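A few compounds are considered here, and "the series" means these few. Any claim that something is new, unique, unknown or untested is made for them only; others in the source may bear on it.

- compound 1 `NC1=N[C@@]2(CO1)c1cc(-c3cncc(C#CC4CC4)c3)ccc1Oc1cnc(C3=CCOCC3)cc12` gives 23 mL.min-1.g-1 in an ADME assay on microsomes from liver (Rattus norvegicus) for metabolic stability, read by LC-MS, using NADPH, with a stated time of 30 min, tested at 1 uM; on this read-out higher numbers stand for fast clearance and lower numbers for slow clearance
- compound 2 `CC#Cc1cncc(-c2ccc3c(c2)[C@@]2(COC(N)=N2)c2cc(C4=CCCOC4)ncc2O3)c1` gives 45 mL.min-1.g-1 in this assay

The values of compound 1 and compound 2 lie within the usual scatter of each other, so compound 2 cannot be ranked apart from compound 1. Compound 3 `CC#Cc1cncc(-c2ccc3c(c2)[C@@]2(COC(N)=N2)c2cc(Cl)ncc2O3)c1` is compound 2 with one chlorine atom in place of a group of 6 heavy atoms, on an aromatic carbon one chlorine atom in place of a group of 6 heavy atoms (5 carbon, 1 oxygen; one six-membered non-aromatic ring with 1 hetero atom), on an aromatic carbon and next to the ring nitrogen. For the measured compounds named here, no measured pair shows this kind of change, so any expectation is uncertain. A modest fall in this assay is expected, an estimated 2.0-fold lower number from compound 2 to compound 3 (0.31 log units; beyond the scatter) that may not clear the scatter. Compound 3 is estimated at 22 mL.min-1.g-1 with 9 mL.min-1.g-1 to 45 mL.min-1.g-1 as the expected range.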

Compound 3, intrinsic clearance in microsomes: 21 mL.min-1.g-1
Beside the measured number, compound 3's estimate is 1.0-fold (0.02 log units) above it; measured number inside the range.
By their numbers in this assay, from the lowest: compounds 3, 1 and 2 (each within the scatter of the next, the first and the last beyond it).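

Replacing the six-membered non-aromatic ring group with chloro, next to the ring nitrogen, gives a 2.1-fold lower number from compound 2 to compound 3 (0.33 log units; beyond the scatter) in this assay. For the compounds shown here, this is the first single-place comparison here, and it shows that the group at this position can move clearance beyond the usual scatter, though only modestly. Nothing measured here explains the step. From the compounds shown here alone, whether the lower number comes from chloro itself or simply from losing the ring remains open. An amine or a methoxy group at this position could help separate those two readings.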